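Paring the Ethoxy Group from Compound 1

This account rests on a few compounds, and the source may have more. Where it says the series, first, only, none or still open, it means among the compounds named here.

Compound 1 `CCOc1ccccc1OCCSC(=S)N[C@H]1CCOC1=O` was tested in a functional assay on DU-145 cells (Homo sapiens) for antiproliferative activity, read by MTT assay, with a stated time of 72 h (on this read-out lower numbers stand for stronger inhibition and higher numbers for weaker inhibition), where compound 1 gives 28300 nM. Among the two numbers shown, compound 1 stands highest; its nearest neighbour, compound 3 `O=C(COc1ccc(C(=O)/C=C/c2cccc(Cl)c2)cc1)N[C@H]1CCOC1=O`, gives 3700 nM, a gap beyond the usual scatter. Compound 2 `Cc1ccc(C(C)C)c(OCCSC(=S)N[C@H]2CCOC2=O)c1` reaches only a limit of the assay, > 64000 nM. Within the data shown here, the single change that turns compound 1 into compound 4 `O=C1OCC[C@@H]1NC(=S)SCCOc1ccccc1` is hydrogen in place of ethoxy on an aromatic carbon. Among the measured compounds shown here, no measured pair shares this change, so its size is unknown from the data. He expects the step of a 1.2-fold higher number from compound 1 to compound 4 (0.09 log units; within the scatter) to stay within the usual scatter or lean toward weaker inhibition. He therefore estimates compound 4 at 35000 nM, with a range from 12000 nM to 100000 nM.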

Compound 4, half-maximal inhibitory concentration: 63800 nM
Beside the measured number, compound 4's estimate is 1.8-fold (0.26 log units) below it; the measured number falls inside the stated range.
By their numbers in this assay, from the lowest: compound 3; then compound 1; then compound 4. At a limit, above all of these: compound 2.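

In this assay, hydrogen in place of ethoxy gives a 2.3-fold higher number from compound 1 to compound 4 (0.35 log units; beyond the scatter), so the ethoxy group on this aromatic carbon, ortho to a large group, carries a modest part of the inhibition seen with the core of compound 1. Compound 2 alone stands at a limit, and compound 4 comes close to it: the limit of > 64000 nM in this assay, at which 1 of the 4 values shown sits.

The compounds shown leave open whether this contribution is specific to ethoxy. How a methoxy group, a longer alkoxy chain or an amine on the same carbon would compare also remains unresolved.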